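This account rests on a few compounds, and the source may have more. Where it says the series, first, only, none or still open, it means among the compounds named here.

Measured so far:
compound 1, `CCC(C)C(NC(=O)NO)C(=O)NC1CCCCC1` — in a functional assay on SW-620 cells (Homo sapiens) for inhibition (on this read-out higher numbers stand for weaker inhibition and lower numbers for stronger inhibition), compound 1 gives > 100000 nM, which is a limit of the assay and not a number.
compound 2, `CCC(C)C1NC(=O)N(C2CCCC2)C1=O` — compound 2 gives > 100000 nM, again a limit of the assay.
compound 3, `CCC(C)C(NC(=O)n1nnc2ccccc21)C(=O)NC(c1ccccc1)c1ccccc1` — compound 3 gives 63500 nM.

Compound 2 stands at the ceiling of this assay, as described by the limit of > 100000 nM in this assay, at which 2 of the 3 values shown sit. Only compound 3 returns a number; compound 2 and compound 1 sit at the limit, so no distance between compound 2 and compound 3 can be stated beyond the fact that one is a number and the other is not.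

Compound 4, `CC(C)C1NC(=O)N(C2CCCC2)C1=O`, differs from compound 2 by hydrogen in place of methyl on a saturated chain carbon, two bonds along the chain from a saturated ring carbon. Within the data shown here, no pair of measured compounds shows this kind of change, so no measured step is available to anchor it. Trimming one carbon from a side chain on a core that already sits at the limit is expected to give no step beyond the usual scatter; the step from compound 2 to compound 4 is estimated as a step that the limit leaves unreadable from compound 2 to compound 4. Compound 4 is therefore expected to return again only a limit, with an estimated value of 150000 nM and a range from 50000 nM to 500000 nM.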

Compound 4, half-maximal inhibitory concentration: > 100000 nM
Compound 4 gave a limit, no number; the forecaster's own chance of this, stated with the estimate: 85%; the middle value does not contradict the limit.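

Compound 2 and compound 4 both return only a limit in this assay, so no step can be read for the change from sec-butyl to isopropyl: the limit of > 100000 nM in this assay, at which 3 of the 4 values shown sit.

The compounds shown leave open whether this change alters inhibition on any core that returns a number.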